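This account rests on a few compounds, and the source may have more. Where it says the series, first, only, none or still open, it means among the compounds named here.

Working notes on the series in an ADME assay on L6 cells (Rattus norvegicus) for cytotoxicity, read by resazurin assay, with a stated time of 72 h; on this read-out higher numbers stand for weaker inhibition and lower numbers for stronger inhibition. Compound 1 (`CN1CCN(CCC(=O)N2CC3C(c4ccccc4)CC(N(C)C)(CC3c3ccccc3)C2)CC1`) gives 13000 nM, compound 2 (`CCN(CC)CCC(=O)N1CC2C(c3ccccc3)CC(N(C)C)(CC2c2ccccc2)C1`) gives 15400 nM and compound 3 (`CN1CCN(CCN2CC3C(c4ccccc4)CC(N(C)C)(CC3c3ccccc3)C2)CC1`) gives 5260 nM, the lowest number of the three.

Compound 4 (`CN(C)C12CC(c3ccccc3)C(CN(CCCN3CCCCC3)C1)C(c1ccccc1)C2`) is not yet measured. Its difference from compound 3 is (piperidin-1-yl)methyl in place of 4-methylpiperazin-1-yl on a saturated chain carbon, two bonds along the chain from an amine nitrogen in a ring; the same change reads 2-(4-methylpiperazin-1-yl)ethyl to 3-(piperidin-1-yl)propyl.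

Among the compounds with values here, the closest precedent is the exchange of the amine group alone, a 1.2-fold higher number from compound 1 to compound 2 (0.07 log units; within the scatter). The two steps that remove the carbonyl are larger, a 2.5-fold lower number from compound 1 to compound 3 (0.39 log units; beyond the scatter) and a 2.9-fold lower number from compound 2 to compound 3 (0.47 log units; beyond the scatter), but they do not apply here, as neither compound 3 nor compound 4 carries that carbonyl. Within the data shown here, no measured step covers the chain lengthening, so the direction stays uncertain.

No change beyond the scatter is expected in this assay, and the estimated step is a 1.3-fold lower number from compound 3 to compound 4 (0.12 log units; within the scatter). For compound 4 the estimated value is 4000 nM, with an expected range from 1600 nM to 10000 nM.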

Compound 4, half-maximal inhibitory concentration: 1750 nM
For compound 4 the middle estimate is 2.3-fold (0.36 log units) above the measured one; the measured number falls inside the stated range.
By their numbers in this assay, from the lowest: compound 4; then compound 3; then compounds 1 and 2 (each within the scatter of the next).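

In this assay, the change from 2-(4-methylpiperazin-1-yl)ethyl to 3-(piperidin-1-yl)propyl on an amine nitrogen in a ring gives a 3.0-fold lower number from compound 3 to compound 4 (0.48 log units; beyond the scatter), so this position responds to a change in the side chain even without a carbonyl, unlike the amine exchange alone in the carbonyl series, a 1.2-fold higher number from compound 1 to compound 2 (0.07 log units; within the scatter). The steps from the carbonyl compounds are larger, an 8.8-fold lower number from compound 2 to compound 4 (0.94 log units; beyond the scatter) and a 7.4-fold lower number from compound 1 to compound 4 (0.87 log units; beyond the scatter), and all three steps to compound 4 lie beyond the scatter. No supporting data bear on why the number falls.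

The step from compound 3 changes chain length and amine together, and a 2-(piperidin-1-yl)ethyl or 3-(4-methylpiperazin-1-yl)propyl group would be needed to separate the two. From the compounds shown here alone, whether a 4-(piperidin-1-yl)butyl chain would extend the trend stays open.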